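This account rests on a few compounds, and the source may have more. Where it says the series, first, only, none or still open, it means among the compounds named here.

Measured so far in an ADME assay on J774 cells (Mus musculus) for cytotoxicity, read by fluorescence and resazurin assay, with a stated time of 24 h; a lower number here means that less compound is tolerated, a higher number that more compound is tolerated:

compound 1, `Cc1cc2cc(NS(=O)(=O)c3ccc([N+](=O)[O-])cc3)ccc2[nH]1`, gives 132000 nM
compound 2, `Cc1cc2cc(NS(=O)(=O)c3ccc(F)cc3)ccc2[nH]1`, gives 40400 nM
compound 3, `O=[N+]([O-])c1ccc(S(=O)(=O)Nc2ccc3cn[nH]c3c2)cc1`, gives only a limit, >= 300000 nM

The value for compound 3 is a limit of this assay and not a number; it sits at the limit of >= 300000 nM in this assay, at which 1 of the 3 values shown sits.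

Within the core of compound 1, the one measured step is a 3.3-fold lower number from compound 1 to compound 2 (0.51 log units; beyond the scatter), a change described as fluoro in place of nitro on an aromatic carbon.

Compound 4, `O=S(=O)(Nc1ccc2cn[nH]c2c1)c1ccc(F)cc1`, is not yet measured in this assay. It relates to compound 3 as compound 2 relates to compound 1: the change is fluoro in place of nitro on an aromatic carbon, and the place descriptions are the same word for word, so this is the same kind of change made on a different core. How the core of compound 3 differs from the core of compound 1 is not broken down here.

For compound 4 in this assay the expected step is an at least 2.0-fold lower number from compound 3 to compound 4 (0.30 log units; that floor lies within the scatter), which rests on the measured step of a 3.3-fold lower number from compound 1 to compound 2 (0.51 log units; beyond the scatter) being carried over to the second core. Since compound 3 gives only a limit, the starting point is not fixed, and a limit for compound 4 is also possible. The estimate for compound 4 in this assay is 150000 nM, with a range from 60000 nM to 350000 nM.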

Compound 4, half-maximal cytotoxic concentration: >= 300000 nM
Compound 4: a limit, no number; the forecaster's own chance of this, stated with the estimate: 35%; middle value at least 2.0-fold (0.30 log units) away from the limit.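

In this assay compound 4 gives >= 300000 nM, a limit of the assay and not a number. Among these compounds, compound 3 also stands at a limit, so no step between compound 3 and compound 4 can be read: the limit of >= 300000 nM in this assay, at which 2 of the 4 values shown sit.

Left open is whether fluoro in place of nitro shifts the number on the core of compound 3 as it does on the core of compound 1, where the step is a 3.3-fold lower number from compound 1 to compound 2 (0.51 log units; beyond the scatter).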